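Swapping the thiophene attachment point in a long-chain amide

A few compounds are considered here, and "the series" means these few. Any claim that something is new, unique, unknown or untested is made for them only; others in the source may bear on it.

Going by the values given here, compound 2 `CCCCCCCCCCCC[C@@H](O)[C@H]1CC[C@H]([C@H](O)CCCCCCCCCCNC(=O)c2ccsc2)O1` stands level with its one measured neighbour. In a functional assay on HBC4 cells (Homo sapiens) for inhibition, read by colorimetric assay and sulforhodamine B assay, with a stated time of 48 h (a higher number here means a weaker inhibitor of growth, a lower number a stronger inhibitor of growth), compound 2 gives 100000 nM. Among the compounds with values here, compound 1 `CCCCCCCCCCCC[C@@H](O)[C@H]1CC[C@H]([C@H](O)CCCCCCCCCCNC(=O)c2cncs2)O1` is the only other compound measured, and in this assay compound 1 gives 100000 nM. The one step recorded, no change at the digits printed from compound 1 to compound 2 (within the scatter), lies within the scatter, so on the numbers shown the two compounds cannot be told apart.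

Compound 3 `CCCCCCCCCCCC[C@@H](O)[C@H]1CC[C@H]([C@H](O)CCCCCCCCCCNC(=O)c2cccs2)O1` is the next member. It differs from compound 2 in one place: thiophen-2-yl in place of thiophen-3-yl on a carbonyl carbon. Within the data shown here, the only measured step that touches this same carbonyl carbon is the exchange from compound 1 to compound 2, and that step produced no change beyond the scatter. Nothing else in the set speaks to a change of the aromatic group here.

He therefore expects the step of no change at the digits printed from compound 2 to compound 3 (within the scatter) to be flat, with no movement beyond the scatter in either direction. His estimate for compound 3 in this assay is 100000 nM, with a range from 40000 nM to 100000 nM, the next measurement to decide whether that holds.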

Compound 3, concentration for 50% growth inhibition: 3390 nM
Compound 3: the middle estimate sits 29-fold (1.47 log units) above what was measured, and the stated range ends above it.
By their numbers in this assay, from the lowest: compound 3; then compounds 1 and 2 (each within the scatter of the next).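

In this assay the attachment point of the thiophene on the carbonyl carbon proves to matter: the two groups have the same atoms and the same counts, yet thiophen-2-yl in place of thiophen-3-yl gives a 29-fold lower number from compound 2 to compound 3 (1.47 log units; beyond the scatter) and is beyond the scatter. Thiophen-2-yl in place of 1,3-thiazol-5-yl likewise gives a 29-fold lower number from compound 1 to compound 3 (1.47 log units; beyond the scatter) on the same carbonyl carbon, so the flat step among the earlier compounds did not mean that this position is indifferent to the aromatic group. Of the three groups shown here, only thiophen-2-yl stands apart from the others, and nothing measured for these compounds offers an explanation for that.

The compounds shown leave open whether the lower number survives a further change at this place, such as a chlorine or a methyl group on the thiophen-2-yl ring, or a furan-2-yl or phenyl group in its place. They also leave open how the thiophen-2-yl amide fares with a shorter or longer chain between the amide nitrogen and the shared core.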